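The source may hold more compounds than are shown below. What is called first, only, known or untested is meant among the compounds shown, and "the series" means these compounds.

Working notes on the series in an assay for inhibition of epoxide hydrolase 1 (Homo sapiens), read by fluorescence, using microsomes; a lower number here means a stronger inhibitor, a higher number a weaker inhibitor.

Compound 1 `O=C(NC(=S)Nc1ccc(Br)c(C(F)(F)F)c1)c1ccccc1` gives 1170 nM in this assay. Compound 2 `O=C(NC(=S)Nc1ccc(Br)cc1)c1ccccc1` gives 3440 nM in this assay, and compound 3 `COc1cc(C)ccc1NC(=S)NC(=O)c1ccccc1` gives 2540 nM in this assay. For the measured compounds named here, compound 2 stands at the highest of the three numbers: against compound 3 the gap is within the scatter, so nothing can be said of their order; against compound 1 the gap is beyond the scatter, and that step is the one measured comparison, a 2.9-fold higher number from compound 1 to compound 2 (0.47 log units; beyond the scatter) for hydrogen in place of trifluoromethyl on an aromatic carbon.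

Compound 4 `O=C(NC(=S)Nc1ccccc1)c1ccccc1` is not yet measured. The change from compound 2 is hydrogen in place of bromo on an aromatic carbon. Going by the values given here, the only step that bears on it is the removal of the trifluoromethyl, a 2.9-fold higher number from compound 1 to compound 2 (0.47 log units; beyond the scatter), which was modest. Removing the bromo is taken as a comparable change, so a modest rise in the number, beyond the scatter but not large, is expected, a 2.0-fold higher number from compound 2 to compound 4 (0.31 log units; beyond the scatter).

Compound 4 is therefore expected at about 7000 nM, with a range from 2500 nM to 20000 nM.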

Compound 4, half-maximal inhibitory concentration: 1290 nM
Compound 4: middle estimate off by 5.4-fold (0.73 log units), on the high side; the whole stated range lies above it.
By their numbers in this assay, from the lowest: compounds 1, 4, 3 and 2 (each within the scatter of the next, the first and the last beyond it).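

In this assay, bromo on this aromatic carbon, para to a large group, is no gain over hydrogen: the change to hydrogen gives a modest fall in the number (a 2.7-fold lower number from compound 2 to compound 4 (0.43 log units; beyond the scatter)). The two measured removals on this ring therefore run in opposite directions, since losing trifluoromethyl raised the number (a 2.9-fold higher number from compound 1 to compound 2 (0.47 log units; beyond the scatter)), so removing a group here has no single effect across the series. Nothing at hand bears on why hydrogen outperforms bromo at this position.

The compounds shown leave open whether the bromo step would keep its direction or size with trifluoromethyl present, as no pair isolates that change. They also leave open how an amine, a carboxylic acid or a longer chain at this position would compare with hydrogen.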